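Ethoxy for methoxy in a two-compound series

The compounds below may be only part of what the source reports. "The series", "measured", "known", "first", "only" and "open" are said of these compounds alone.

Measured so far in a functional assay on MDA-MB-468 cells (Homo sapiens) for antiproliferative activity; on this read-out higher numbers stand for weaker inhibition of growth and lower numbers for stronger inhibition of growth
- compound 1 `COc1ccc(-c2nc3cc(F)ccc3s2)cc1Br` gives 420 nM
- compound 2 `CCOc1cc(-c2nc3cc(F)ccc3s2)ccc1OC` gives 92 nM

Compound 2 holds the lower of the two numbers, and its gap to compound 1 lies beyond the scatter. Compound 3 `CCOc1ccc(-c2nc3cc(F)ccc3s2)cc1OCC` differs from compound 2 by methyl in place of hydrogen on a saturated chain carbon bound to an oxygen on an aromatic ring (methoxy to ethoxy). Going by the values given here, the only measured step (a 4.6-fold lower number from compound 1 to compound 2 (0.66 log units; beyond the scatter)) is a different change, ethoxy in place of bromo, so it bears only loosely on this one. It shows that a single group swap can move this read-out, but it gives no direction for methoxy to ethoxy. Its size serves as a rough upper guide, so a smaller move is expected, with a slight and weakly supported lean upward. In this assay the expected result is a 1.5-fold higher number from compound 2 to compound 3 (0.18 log units; within the scatter) (an estimate with a wide margin). For compound 3 the estimated value is 140 nM (range 45 nM to 450 nM).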

Compound 3, concentration for 50% growth inhibition: 55 nM
Compound 3: the middle estimate sits 2.5-fold (0.41 log units) above what was measured, within the range that was stated.
By their numbers in this assay, from the lowest: compounds 3 and 2 (each within the scatter of the next); then compound 1.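

Methyl in place of hydrogen on the saturated chain carbon bound to an oxygen on an aromatic ring, methoxy to ethoxy, gives a 1.7-fold lower number from compound 2 to compound 3 (0.22 log units; within the scatter) in this assay. The earlier step compared only bromo with ethoxy; this one shows that the site accepts a methyl while compound 3 remains within the scatter of compound 2, so the two cannot be told apart on this read-out. No available evidence offers an explanation for this result.

From the compounds shown here alone, whether the site also accepts a longer chain, such as propoxy or butoxy, remains open, as does the effect of an amine or a carboxylic acid at the end of that chain. Going by these compounds, the same methoxy to ethoxy change on other versions of the core also remains open.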